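A few compounds are considered here, and "the series" means these few. Any claim that something is new, unique, unknown or untested is made for them only; others in the source may bear on it.

Among the compounds with values here, compound 2 `COC[C@H](NC1CCN(CCCc2c[nH]c3ccc(-n4cnnc4)cc23)CC1)c1ccccc1` gives the lower of the two numbers measured so far in an assay on CHO cells for agonist activity at 5-hydroxytryptamine receptor 1D (Homo sapiens), read by GTPgammaS binding; a lower number here means that less compound is needed, a higher number that more compound is needed for the effect: compound 2 gives 0.9 nM. Within the data shown here, its nearest neighbour is compound 1 `O=S(=O)(NCC1CCN(CCCc2c[nH]c3ccc(-n4cnnc4)cc23)CC1)c1ccccc1`, which in this assay gives 12 nM; the single step recorded, a 13-fold lower number from compound 1 to compound 2 (1.12 log units; beyond the scatter), replaced the group on the saturated ring carbon as a whole. Compound 3 `NC(=O)OC[C@H](NC1CCN(CCCc2c[nH]c3ccc(-n4cnnc4)cc23)CC1)c1ccccc1` keeps the framework of compound 2 and changes only the terminus of the side chain: carbamoyl in place of methyl on an oxygen on a saturated carbon. Among the measured compounds shown here, no measured step touches this oxygen, so the one step that exists, from compound 1 to compound 2, speaks only to the general tolerance of this region for varied groups and not to this exchange. Compound 3 is therefore expected to stay close to compound 2, with a step of a 1.7-fold higher number from compound 2 to compound 3 (0.22 log units; within the scatter) that need not exceed the scatter. The estimate for compound 3 is 1.5 nM, within a range from 0.5 nM to 5 nM.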

Compound 3, half-maximal effective concentration: 9.3 nM
Compound 3: the middle estimate sits 6.2-fold (0.79 log units) below what was measured; measured number outside the range, above it.
By their numbers in this assay, from the lowest: compound 2; then compounds 3 and 1 (each within the scatter of the next).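

In this assay, methoxy gives way to carbamoyloxy with a 10-fold higher number from compound 2 to compound 3 (1.01 log units; beyond the scatter) as the result, so the end of this side chain is not a free position: a change confined to the group on an oxygen on a saturated carbon is enough to move the number beyond the scatter. The earlier step replaced the whole group on the saturated ring carbon and could not show what this terminus alone contributes. Nothing available bears on why the number rises.

The compounds shown leave open whether a hydroxyl, an ethoxy or an amine at this place would stay near compound 2 or move as far as compound 3. They also leave open whether a methylcarbamoyl group, or a longer chain carrying the carbamoyl group, would behave as the carbamoyl group of compound 3 does.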